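This account rests on a few compounds, and the source may have more. Where it says the series, first, only, none or still open, it means among the compounds named here.

Measured in a functional assay on NCI-H1975 cells (Homo sapiens) for cytotoxicity, read by MTT assay, with a stated time of 72 h; a higher number here means a weaker inhibitor, a lower number a stronger inhibitor:
- compound 1 `CN1CCN(c2ccc(Nc3ncc4nc(Nc5ccccc5)n(C5CCCCC5)c4n3)cc2)CC1`: 390 nM
- compound 2 `CC1CCN(c2ccc(Nc3ncc4nc(Nc5ccccc5)n(C5CCCC5)c4n3)cc2)CC1`: 9800 nM
- compound 3 `CN1CCN(c2ccc(Nc3ncc4nc(Nc5cccc([N+](=O)[O-])c5)n(C5CCCC5)c4n3)cc2)CC1`: 980 nM

Compound 3 holds the middle place of the three numbers in this assay, with gaps on both sides that lie beyond the scatter. Its number is higher than that of compound 1 and lower than that of compound 2.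

Compound 4 `Cc1cccc(Nc2nc3cnc(Nc4ccc(N5CCN(C)CC5)cc4)nc3n2C2CCCC2)c1` has methyl in place of nitro on an aromatic carbon. Among the compounds with values here, no pair of measured compounds differs in one place only, so the series gives no direct measure of this change. Compound 1 and compound 2 both lack the nitro, yet their numbers lie on opposite sides of compound 3, and both also differ from it elsewhere. A small step towards a lower number, within the scatter, is therefore expected in this assay. The expected change is a 1.4-fold lower number from compound 3 to compound 4 (0.15 log units; within the scatter). For compound 4 the estimated value is 700 nM, with an expected range of 250 nM to 2200 nM.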

Compound 4, half-maximal inhibitory concentration: 560 nM
The estimate for compound 4 lay 1.3-fold (0.10 log units) above the measured number; the range from low to high includes it.
By their numbers in this assay, from the lowest: compounds 1, 4 and 3 (each within the scatter of the next, the first and the last beyond it); then compound 2.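

The pair gives the series its first single-place measure. In this assay the step from 3-nitrophenyl to 3-methylphenyl is a 1.8-fold lower number from compound 3 to compound 4 (0.24 log units; within the scatter) and so gives no real separation between the two compounds, although nitro, with its hydrogen-bond acceptors, gives way to a smaller methyl with none. At this position, therefore, the number in this cell assay does not depend on keeping the nitro, at least with methyl as its replacement, but no measurement at hand accounts for this.

Open, on these data alone, is how an amine or a carboxylic acid on the same aromatic carbon would compare with nitro and methyl. A single step also cannot show whether this replacement would read the same way with another group elsewhere on the shared core.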